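From a fluoro group to a nitro group on the aromatic carbon

The source may hold more compounds than are shown below. What is called first, only, known or untested is meant among the compounds shown, and "the series" means these compounds.

Within the data shown here, compound 2 `Fc1ccc(OCC2=NCCO2)cc1` stands lower of the two compounds measured so far: in a functional assay on the whole organism for inhibition, with Rattus norvegicus as the target, read by paw edema, with a stated time of 30 min, at a dose of 80 mg/kg by the oral route (on this read-out lower numbers stand for a weaker effect and higher numbers for a stronger effect at the one dose given), compound 2 gives 40.5%, while compound 1 `Brc1ccc(OCC2=NCCO2)cc1` gives 60.1%. Among the measured compounds shown here, the one step recorded, a number 19.6 percentage points lower from compound 1 to compound 2 (beyond the scatter), concerns the same aromatic carbon that changes next. Compound 3 `O=[N+]([O-])c1ccc(OCC2=NCCO2)cc1` differs from compound 2 in one place: nitro in place of fluoro on an aromatic carbon. For the measured compounds named here, no measured step involves a nitro group, so the direction is open; the recorded step only shows that a swap at this carbon can move the read-out beyond the scatter. A step of a number 11.5 percentage points higher from compound 2 to compound 3 (beyond the scatter) is therefore expected, with wide uncertainty. Compound 3 is estimated at 52%, within 32% to 72%.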

Compound 3, a percentage reported as inhibition, in the whole organism at one dose (the size of the read-out at that dose, not a potency): 77.1%
For compound 3 the middle estimate is 25.1 percentage points below the measured one; the whole stated range lies below it.
By their numbers in this assay, from the lowest: compound 2; then compound 1; then compound 3.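

In this assay, nitro in place of fluoro gives a number 36.6 percentage points higher from compound 2 to compound 3 (beyond the scatter), and nitro in place of bromo gives a number 17 percentage points higher from compound 1 to compound 3 (beyond the scatter). Compound 3 therefore stands above both halogen compounds, so the bromo group does not mark the top of the read-out at this aromatic carbon, and the fluoro to nitro swap is the largest step seen here so far. Nothing measured here explains this result. From the compounds shown here alone, whether an amine, a carboxylic acid or a nitrile at this carbon would match the nitro group remains open, as does the effect of moving the nitro group elsewhere on the ring.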